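Swapping an Imidazole for an Oxadiazolone on the Side Chain

The compounds below may be only part of what the source reports. "The series", "measured", "known", "first", "only" and "open" are said of these compounds alone.

Compound 1 (`CC(C)C(Cc1ncc[nH]1)c1ccc(-c2ccc3cccc(F)c3c2)[nH]c1=O`) was tested in an ADME assay on microsomes from liver (Mus musculus) for metabolic stability; on this read-out lower numbers stand for a shorter-lived compound and higher numbers for a longer-lived compound. In this assay compound 1 gives only a limit, < 0.0667 h, so its true value is not known. Compound 2 (`CCC(CC)(c1nnc[nH]1)c1ccc(-c2ccc3cccc(F)c3c2)[nH]c1=O`), on the same core but differing in several places, gives 0.447 h in this assay. Compound 3 (`CC(C)C(Cc1noc(=O)[nH]1)c1ccc(-c2ccc3cccc(F)c3c2)[nH]c1=O`) differs from compound 1 by a group of 6 heavy atoms (2 carbon, 2 nitrogen, 2 oxygen; one five-membered aromatic ring with 3 hetero atoms) in place of a group of 5 heavy atoms (3 carbon, 2 nitrogen; one five-membered aromatic ring with 2 hetero atoms), on a saturated chain carbon, two bonds along the chain from an aromatic carbon. Within the data shown here, no single-change step has been measured, so the size of this one is uncertain. The expected step is an at least 1.4-fold higher number from compound 1 to compound 3 (0.17 log units; that floor lies within the scatter), a modest gain, because compound 1 already sits at the limit of < 0.0667 h in this assay, at which 1 of the 2 values shown sits. Compound 3 is therefore estimated at 0.1 h, within 0.03 h to 0.35 h.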

Compound 3, half-life: 2.78 h
Beside the measured number, compound 3's estimate is 28-fold (1.44 log units) below it; the measured number lies above the stated range.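

Placed on a saturated chain carbon, two bonds along the chain from an aromatic carbon, the group of 6 heavy atoms in place of 1H-imidazol-2-yl gives an at least 41-fold higher number from compound 1 to compound 3 (1.61 log units; beyond the scatter) in this assay. This single change therefore moves the read-out strongly, which compounds 1 and 2, differing in several places, could not show. Compound 1 gives only a limit, so the full size of the step stays unknown: the limit of < 0.0667 h in this assay, at which 1 of the 3 values shown sits.

On these data alone, how a carboxylic acid in this place would compare remains open. So does whether the same swap would act alike on a different side chain.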